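Aryl swap on the amide of compound 1

This account rests on a few compounds, and the source may have more. Where it says the series, first, only, none or still open, it means among the compounds named here.

Compound 1 `Cc1ccc(NC(=O)CN2CCN(c3nnc(Cc4ccncc4)c4ccccc34)CC2)c(C)c1` gives 45000 nM
Compound 2 `O=C(CN1CCN(c2nnc(Cc3ccccc3)c3ccccc23)CC1)Nc1ccc(F)c(C(F)(F)F)c1` gives 2480 nM
Compound 3 `O=C(CN1CCN(c2nnc(Cc3ccccc3)c3ccccc23)CC1)Nc1cc(C(F)(F)F)ccc1Cl` gives 89000 nM

These values come from a functional assay on A549 cells (Homo sapiens) for cytotoxicity, read by MTT assay, with a stated time of 72 h; a higher number here means a weaker inhibitor, a lower number a stronger inhibitor. There, compound 1 at 45000 nM and compound 3 at 89000 nM lie within the scatter of each other, so the two cannot be told apart. Compound 2, at 2480 nM, has a clearly lower number than either.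

Compound 4 `O=C(CN1CCN(c2nnc(Cc3ccncc3)c3ccccc23)CC1)Nc1ccc(F)c(Cl)c1` keeps the core of compound 1 and carries 3-chloro-4-fluorophenyl in place of 2,4-dimethylphenyl on an amide-type nitrogen.

Within the data shown here, only one measured step changes the group on this nitrogen: a 36-fold higher number from compound 2 to compound 3 (1.55 log units; beyond the scatter). That large step, with 2-chloro-5-(trifluoromethyl)phenyl in place of 4-fluoro-3-(trifluoromethyl)phenyl, shows that this group can move the number a long way. The entering group of compound 4 has a name close to that of the group on compound 2, which gives 2480 nM, so a move towards a lower number seems likely. Among the measured compounds shown here, no measured step starts from compound 1, however, so this reading is uncertain and the expected move is modest.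

The expected change is a 4.5-fold lower number from compound 1 to compound 4 (0.65 log units; beyond the scatter).

Compound 4 is estimated at 10000 nM, with an expected range from 2500 nM to 40000 nM.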

Compound 4, half-maximal inhibitory concentration: 12300 nM
Estimate against measurement, compound 4: 1.2-fold (0.09 log units) below; the range from low to high includes it.
By their numbers in this assay, from the lowest: compound 2; then compound 4; then compounds 1 and 3 (each within the scatter of the next).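

Replacing 2,4-dimethylphenyl with 3-chloro-4-fluorophenyl on the amide-type nitrogen gives a 3.7-fold lower number from compound 1 to compound 4 (0.56 log units; beyond the scatter) in this assay, so the group at this position also moves the number on the core of compound 1, and not only on the core shared by compound 2 and compound 3. This modest step is smaller than the large one seen earlier, a 36-fold higher number from compound 2 to compound 3 (1.55 log units; beyond the scatter), and it occurs although both groups have the same count of heavy atoms and the same single carbon-only aromatic ring, with two methyl groups giving way to chlorine and fluorine. No measurement shown here accounts for the change in number.

The compounds shown leave open whether the chlorine, the fluorine or their placing on the ring accounts for the step, as no compound here carries one of these halogens alone on the core of compound 1. Going by these compounds, it also remains open how the number would respond to a different kind of group on this ring, such as an amine or a carboxylic acid.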